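The source may report more compounds than this note shows. Statements on the series, on what has been measured and on what is new or still open speak of the compounds shown alone.

Three compounds share a common core and were tested in an ADME assay on MT4 cells (Homo sapiens) for cytotoxicity, read by MTT assay, with a stated time of 4 days; on this read-out lower numbers stand for higher toxicity in this test and higher numbers for lower toxicity in this test. Compound 1, with the structure `Cc1c(Cc2c(F)cccc2F)nc(N(C)C)[nH]c1=O`, reaches only a limit of the assay and no number: in this assay compound 1 gives > 89000 nM. Compound 2, with the structure `CCN(C)c1nc(Cc2c(F)cccc2F)c(C)c(=O)[nH]1`, likewise reaches a limit of the assay and no number: in this assay compound 2 gives > 85000 nM. Within the data shown here, compound 3, with the structure `CC(c1cc(=O)[nH]c(N(C)C)n1)c1c(F)cccc1F`, is the one that gives a number: in this assay compound 3 gives 89000 nM. Compound 3 and compound 1 have the same atoms joined differently; the difference between the two cores is not broken down here.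

From compound 1 to compound 2 the change is methyl in place of hydrogen on a saturated chain carbon bound to a nitrogen on an aromatic ring, and the step in this assay is a step that the two limits leave unreadable from compound 1 to compound 2, as both values sit at a limit, the limit of > 89000 nM in this assay, at which 1 of the 3 values shown sits, and (the limit of > 85000 nM in this assay, at which 1 of the 3 values shown sits).

Compound 4, with the structure `CCC(c1cc(=O)[nH]c(N(C)C)n1)c1c(F)cccc1F`, is not yet measured. It differs from compound 3 by methyl in place of hydrogen on a saturated chain carbon, two bonds along the chain from two aromatic carbons, the same kind of change, though the place differs: on a saturated chain carbon bound to a nitrogen on an aromatic ring for the first pair, on a saturated chain carbon, two bonds along the chain from two aromatic carbons for the second. Because compound 3 gives 89000 nM and the measured step of this kind could not be read, the step from compound 3 to compound 4 is expected to be a 1.0-fold lower number from compound 3 to compound 4 (0.02 log units; within the scatter). Compound 4 is thus estimated to give 85000 nM in this assay, between 40000 nM and 100000 nM, and a limit rather than a number is quite possible.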

Compound 4, half-maximal cytotoxic concentration: 73000 nM
The estimate for compound 4 lay 1.2-fold (0.07 log units) above the measured number, and the stated range covers the measured number.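

In this assay, methyl in place of hydrogen on a saturated chain carbon, two bonds along the chain from two aromatic carbons, gives a 1.2-fold lower number from compound 3 to compound 4 (0.09 log units; within the scatter), so on the core of compound 3 this change stays within the usual scatter. The step of the same kind on the core of compound 1 cannot be read, as compound 1 and compound 2 both stand at limits of the assay, and that change also sits in another place, on a saturated chain carbon bound to a nitrogen on an aromatic ring. Among these compounds, the series thus offers only one readable step of this kind, which shows nothing about whether the change carries from one core to the other.

The compounds shown leave open whether a longer chain such as propyl would stay within the scatter at the place changed from compound 3 to compound 4. They also leave open how an amine or a carboxylic acid at that place would read in this assay.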